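Replacing Cyclohexyl with 4-Chlorobenzyl on the Shared Core

The compounds below may be only part of what the source reports. "The series", "measured", "known", "first", "only" and "open" are said of these compounds alone.

Compound 2 `O=C(O)c1ccccc1-c1ccc(CCc2ncc(C3CCCCC3)[nH]2)cc1` has been tested in an in vitro functional assay on cells for agonist activity at Bombesin receptor subtype-3 (Mus musculus), read by luminescence and calcium flux (a higher number here means that more compound is needed for the effect, a lower number that less compound is needed), where compound 2 gives 14.7 nM. For the measured compounds named here, this is the higher of the two numbers measured so far. Going by the values given here, the only other compound, compound 1 `O=C(O)c1ccccc1-c1ccc(CCc2ncc(CC3CCC3)[nH]2)cc1`, gives 7.1 nM in this assay. Among the compounds with values here, the single measured step between them is a 2.1-fold higher number from compound 1 to compound 2 (0.32 log units; beyond the scatter), and it is the only point of comparison available.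

Compound 3 `O=C(O)c1ccccc1-c1ccc(CCc2ncc(Cc3ccc(Cl)cc3)[nH]2)cc1` differs from compound 2 in one place: 4-chlorobenzyl in place of cyclohexyl on an aromatic carbon. The measured step, in which cyclohexyl replaced cyclobutylmethyl, was modest, so the group at this position seems to shift the number only moderately. Within the data shown here, the new change introduces an aromatic ring carrying a chlorine, something neither measured compound contains, so there is no direct precedent for its effect. Among the measured compounds shown here, with only one modest step as a guide, a small change in either direction, or none beyond the scatter, is the most reasonable expectation. The expected step is a 1.5-fold lower number from compound 2 to compound 3 (0.17 log units; within the scatter). Compound 3 is therefore estimated to give about 10 nM in this assay, with a likely range from 3.5 nM to 30 nM.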

Compound 3, half-maximal effective concentration: 102 nM
Beside the measured number, compound 3's estimate is 10-fold (1.01 log units) below it; measured number above the stated range.
By their numbers in this assay, from the lowest: compound 1; then compound 2; then compound 3.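

Among the groups shown at this position, the two with a saturated carbon ring sit fairly close together, but the aromatic group does not: in this assay, 4-chlorobenzyl in place of cyclohexyl gives a 6.9-fold higher number from compound 2 to compound 3 (0.84 log units; beyond the scatter) and so needs clearly more compound for the effect. The contrast with compound 1 is wider still, with 4-chlorophenyl in place of cyclobutyl on the saturated chain carbon giving a 14-fold higher number from compound 1 to compound 3 (1.16 log units; beyond the scatter) and a step classed as large. So this position, on an aromatic carbon of the five-membered ring, is more sensitive to the choice of group than the earlier pair could show, although no measurement explains why the number rises.

The compounds shown do not separate the contribution of the aromatic ring from that of its chlorine, since both arrive together in compound 3. A plain benzyl group would test the chlorine on its own, and a cyclohexylmethyl group would show whether a saturated ring on the same one-carbon link behaves like cyclobutylmethyl or like 4-chlorobenzyl.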